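This account rests on a few compounds, and the source may have more. Where it says the series, first, only, none or still open, it means among the compounds named here.

Measured compounds:
compound 1 `CC(C)OC(=O)C1CN(C(=O)c2ccc(F)cc2)CC(C)(C)c2cc(C#N)[nH]c21` — 640 nM
compound 2 `CC(C)OC(=O)C1=CN(C(=O)c2ccc(F)c(F)c2)CC(C)(C)c2cc(C#N)[nH]c21` — 6.3 nM
compound 3 `CC(C)OC(=O)C1CN(C(=O)c2ccc(C#N)cc2)CC(C)(C)c2cc(C#N)[nH]c21` — 5700 nM

In an assay on HEK293 cells for agonist activity at Bile acid receptor (Homo sapiens), read by a luciferase reporter (on this read-out lower numbers stand for an effect already at smaller amounts and higher numbers for an effect only at larger amounts of compound), compound 2 stands lowest of the three numbers: compound 1 lies a long way above it, and compound 3 further still, both gaps beyond the scatter. Compound 4 `CC(C)OC(=O)C1=CN(C(=O)c2cccc(Cl)c2)CC(C)(C)c2cc(C#N)[nH]c21` is not yet measured. It differs from compound 2 in a single place: 3-chlorophenyl in place of 3,4-difluorophenyl on a carbonyl carbon.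

Going by the values given here, only one measured step touches the same part of the molecule, the group on the carbonyl carbon. There, an 8.9-fold higher number from compound 1 to compound 3 (0.95 log units; beyond the scatter). Among the compounds with values here, that change is not the same as the one from compound 2 to compound 4, and both groups involved here carry only halogen; no measured pair shows chloro against fluoro, or a single halogen against two. Within the data shown here, the one step in this region is modest, so a modest step is expected, more likely toward a higher number, with the chance of no step beyond the scatter remaining real. Compound 4 is therefore estimated at 15 nM, within 4 nM to 60 nM, which means an expected 2.4-fold higher number from compound 2 to compound 4 (0.38 log units; beyond the scatter).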

Compound 4, half-maximal effective concentration: 12 nM
For compound 4 the middle estimate is 1.3-fold (0.10 log units) above the measured one; low and high end bracket the measured number.
By their numbers in this assay, from the lowest: compounds 2 and 4 (each within the scatter of the next); then compound 1; then compound 3.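

In this assay, going by these compounds alone, the first pair of compounds carrying only halogen on the aryl group at this carbonyl carbon reads alike: a 1.9-fold higher number from compound 2 to compound 4 (0.28 log units; within the scatter). Within the data shown here, the only earlier step at this carbonyl carbon, an 8.9-fold higher number from compound 1 to compound 3 (0.95 log units; beyond the scatter), lay beyond the scatter and brought in a cyano group, whereas 3-chlorophenyl and 3,4-difluorophenyl cannot be told apart here, so the position accepts either halogen pattern with compound 2 and compound 4 both staying in the low nanomolar range. Nothing at hand accounts for this match between the two groups.

Because the number and the kind of halogen differ together in this one pair, their separate contributions remain unresolved. As far as these compounds go, how this series responds to a methoxy group or an amine on the phenyl ring, or to a plain unsubstituted phenyl at the same carbonyl carbon, also stays open.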